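This account rests on a few compounds, and the source may have more. Where it says the series, first, only, none or still open, it means among the compounds named here.

Three compounds of the series share one core and differ only in the group on an aromatic carbon of that core. Compound 1 `CCc1cc(C(=O)O)nc2ccc(-c3ccc(OCc4c(-c5c(Cl)cccc5Cl)noc4C(C)C)cc3)cc12` carries ethyl, and in a functional assay for agonist activity at Bile acid receptor (Homo sapiens), read by FRET (a higher number here means that more compound is needed for the effect, a lower number that less compound is needed), compound 1 gives 75 nM. Compound 2 `CCOc1cc(C(=O)O)nc2ccc(-c3ccc(OCc4c(-c5c(Cl)cccc5Cl)noc4C(C)C)cc3)cc12` carries ethoxy, and in this assay compound 2 gives 52 nM. Compound 3 `CCCOc1cc(C(=O)O)nc2ccc(-c3ccc(OCc4c(-c5c(Cl)cccc5Cl)noc4C(C)C)cc3)cc12` carries propoxy, and in this assay compound 3 gives 59 nM. On these numbers compound 3 stands second highest of the three; the nearest value is that of compound 2, with a 1.1-fold higher number from compound 2 to compound 3 (0.05 log units; within the scatter), the furthest that of compound 1, with a 1.3-fold lower number from compound 1 to compound 3 (0.10 log units; within the scatter). The remaining step, a 1.4-fold lower number from compound 1 to compound 2 (0.16 log units; within the scatter), also stays within the scatter, so nothing among the three separates beyond it.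

Compound 4 `CC(C)COc1cc(C(=O)O)nc2ccc(-c3ccc(OCc4c(-c5c(Cl)cccc5Cl)noc4C(C)C)cc3)cc12` is reached from compound 3 by methyl in place of hydrogen on a saturated chain carbon bound to two saturated chain carbons; cut one bond further out this reads propoxy to isobutoxy. The step that bears on it most closely is a 1.1-fold higher number from compound 2 to compound 3 (0.05 log units; within the scatter), where a methyl added to the same chain moved nothing beyond the scatter. No step beyond the scatter is therefore expected, and a 1.0-fold higher number from compound 3 to compound 4 (0.01 log units; within the scatter) is the expected size. Compound 4 is expected to give 60 nM in this assay, within a range from 30 nM to 120 nM.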

Compound 4, half-maximal effective concentration: 78 nM
Estimate against measurement, compound 4: 1.3-fold (0.11 log units) below; the range from low to high includes it.
By their numbers in this assay, from the lowest: compounds 2, 3, 1 and 4 (each within the scatter of the next).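

Propoxy to isobutoxy puts a methyl on the saturated chain carbon bound to two saturated chain carbons, and in this assay this gives a 1.3-fold higher number from compound 3 to compound 4 (0.12 log units; within the scatter); a branched chain on this aromatic carbon therefore stays level with the straight one. The wider comparisons, a 1.5-fold higher number from compound 2 to compound 4 (0.18 log units; within the scatter) and a 1.0-fold higher number from compound 1 to compound 4 (0.02 log units; within the scatter), also stay within the scatter, so ethyl, ethoxy, propoxy and isobutoxy are not separated at this position. No measurement at hand accounts for how closely these four values lie.

On these data alone, it remains open whether any group on this aromatic carbon moves the number beyond the scatter, for example an amine, a hydroxyl or a longer chain such as hexyloxy. A ring on the chain, as in cyclopropylmethoxy or benzyloxy, also remains to be read against isobutoxy.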